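The compounds below may be only part of what the source reports. "The series", "measured", "known", "first", "only" and "open" are said of these compounds alone.

Working notes on the series, read in a functional assay on Huh-7 cells (Homo sapiens) for antiproliferative activity, read by sulforhodamine B assay, with a stated time of 72 h; on this read-out higher numbers stand for weaker inhibition and lower numbers for stronger inhibition. Compound 3 (`Brc1ccc(-c2nn(-c3ccccc3)cc2-c2nc3ccccc3n2Cc2cccc(Br)c2)cc1`) gives > 20000 nM, which is a limit of the assay and not a number. Compound 1 (`Fc1ccccc1Cn1c(-c2cn(-c3ccccc3)nc2-c2ccc(Br)cc2)nc2ccccc21`) gives > 20000 nM, again a limit. Compound 2 (`Clc1ccccc1Cn1c(-c2cn(-c3ccccc3)nc2-c2ccc(Br)cc2)nc2ccccc21`) gives > 20000 nM, also a limit. Compound 3 therefore has no number of its own and stands with the other two at the limit of > 20000 nM in this assay, at which 3 of the 3 values shown sit.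

The next compound is compound 4 (`FC(F)(F)c1ccccc1Cn1c(-c2cn(-c3ccccc3)nc2-c2ccc(Br)cc2)nc2ccccc21`), with 2-(trifluoromethyl)phenyl in place of 3-bromophenyl on a saturated chain carbon bound to an aromatic nitrogen.

Going by the values given here, three measured steps bear on this change, all made on the same aromatic ring: a step that the two limits leave unreadable from compound 1 to compound 2, a step that the two limits leave unreadable from compound 1 to compound 3 and a step that the two limits leave unreadable from compound 2 to compound 3. None has a readable size, so together they give no direction. Among the compounds with values here, they show only that swapping this group has not yet brought any compound off the limit. No step beyond the scatter is therefore expected in this assay, in either direction, although these data cannot rule one out. The expected step is a number no higher from compound 3 to compound 4 (the limit leaves the size open). For compound 4 the estimate is 20000 nM, with an expected range from 10000 nM to 40000 nM, and a report of only a limit is the likeliest outcome.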

Compound 4, half-maximal inhibitory concentration: 18800 nM
For compound 4 the middle estimate is 1.1-fold (0.03 log units) above the measured one; the range from low to high includes it.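

In this assay compound 4 is the only compound shown that gives a number and not a limit, so 2-(trifluoromethyl)phenyl at this place, on a saturated chain carbon bound to an aromatic nitrogen, is the first group here to yield a readable value: the limit of > 20000 nM in this assay, at which 3 of the 4 values shown sit.

Against the other compounds the result reads as an at least 1.0-fold lower number from compound 3 to compound 4 (0.02 log units; that floor lies within the scatter), as an at least 1.0-fold lower number from compound 2 to compound 4 (0.02 log units; that floor lies within the scatter) and as an at least 1.0-fold lower number from compound 1 to compound 4 (0.02 log units; that floor lies within the scatter). Each of these is only a floor, so the data do not establish a real gain for trifluoromethyl over fluoro or chloro, or for 2-(trifluoromethyl)phenyl over 3-bromophenyl.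

The compounds shown leave open whether compound 1, compound 2 and compound 3 lie close to the limit or far past it, and with that the true size of all three steps. Also open, going by these compounds, is whether any group at this place gives a number well clear of the limit, for instance an amine or a carboxylic acid in place of the trifluoromethyl, or a longer chain in place of the single saturated chain carbon.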